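Methoxy to methylsulfanyl on the pyrimidine ring: compound 4

A few compounds are considered here, and "the series" means these few. Any claim that something is new, unique, unknown or untested is made for them only; others in the source may bear on it.

Measured compounds:
- compound 1 `COc1ncnc2c1c(I)cn2[C@@H]1O[C@H](CO)[C@@H](O)[C@H]1O` gives 63000 nM in an ADME assay on MRC5 cells (Homo sapiens), read by MTT assay, with a stated time of 72 h; a higher number here means a weaker inhibitor, a lower number a stronger inhibitor
- compound 2 `COc1ncnc2c1c(-c1cccs1)cn2[C@@H]1O[C@H](CO)[C@@H](O)[C@H]1O` gives 43200 nM in this assay
- compound 3 `COc1ncnc2c1c(-c1ccco1)cn2[C@@H]1O[C@H](CO)[C@@H](O)[C@H]1O` gives 1700 nM in this assay

Compound 2 holds the second highest of the three numbers in this assay. Its nearest neighbour is compound 1, with a 1.5-fold lower number from compound 1 to compound 2 (0.16 log units; within the scatter). Its furthest is compound 3, with a 25-fold lower number from compound 2 to compound 3 (1.41 log units; beyond the scatter); the same kind of gap shows in a 37-fold lower number from compound 1 to compound 3 (1.57 log units; beyond the scatter).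

Compound 4 `CSc1ncnc2c1c(-c1cccs1)cn2[C@@H]1O[C@H](CO)[C@@H](O)[C@H]1O` differs from compound 2 in one place: methylsulfanyl in place of methoxy on an aromatic carbon. None of the three measured steps bears on this change; all of them concern the group on the five-membered ring, whereas the change to compound 4 sits on the six-membered aromatic ring with 2 nitrogen. Going by the values given here, the series therefore gives no direct guide, and with no measured step to lean on, the expectation is a step of no size beyond the scatter in this assay.

Compound 4 is estimated at 40000 nM, with a range from 15000 nM to 100000 nM. This estimate means a step of a 1.1-fold lower number from compound 2 to compound 4 (0.03 log units; within the scatter) is expected.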

Compound 4, half-maximal inhibitory concentration: > 100000 nM
Compound 4 ended at the assay's limit (the forecaster's own chance of this, stated with the estimate: 15%); middle value at least 2.5-fold (0.39 log units) away from the limit.
By their numbers in this assay, from the lowest: compound 3; then compounds 2 and 1 (each within the scatter of the next). At a limit, above all of these: compound 4.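

Methoxy on the six-membered aromatic ring with 2 nitrogen is not a neutral position in this assay: with thiophen-2-yl held fixed, methylsulfanyl in its place gives an at least 2.3-fold higher number from compound 2 to compound 4 (0.36 log units; beyond the scatter). Compound 4 stands at a limit of the assay and not at a number, so the step has a floor but no known size: the limit of > 100000 nM in this assay, at which 1 of the 4 values shown sits. Going by these compounds alone, the earlier steps showed only that the group on the five-membered ring moves the number, and this step shows that the six-membered ring position moves it too, towards a weaker inhibitor.

From the compounds shown here alone, whether methylsulfanyl gives a step of the same direction alongside furan-2-yl or iodo remains open. Also open, going by these compounds, is what an amine or a longer chain such as ethoxy would give at this position.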